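From Methoxy to Benzyloxy on Compound 2

The source may report more compounds than this note shows. Statements on the series, on what has been measured and on what is new or still open speak of the compounds shown alone.

Compound 1 `O=C(/C(=C\c1ccccc1OCc1ccccc1)Sc1ccc(F)cc1)c1ccc(Cl)cc1`: 1000 nM
Compound 2 `COc1ccccc1/C=C(/SCc1ccc(C)cc1)C(=O)c1ccc(Cl)cc1`: 10000 nM

Among the compounds with values here, only two compounds have been measured in a functional assay on DU-145 cells (Homo sapiens) for inhibition, read by trypan blue exclusion, with a stated time of 96 h; on this read-out higher numbers stand for weaker inhibition of growth and lower numbers for stronger inhibition of growth. Of these, compound 2 has the higher number at 10000 nM, meaning weaker inhibition. The gap down to compound 1 at 1000 nM lies beyond the scatter.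

Compound 3 `Cc1ccc(CS/C(=C/c2ccccc2OCc2ccccc2)C(=O)c2ccc(Cl)cc2)cc1` differs from compound 2 in one place: phenyl in place of hydrogen on a saturated chain carbon bound to an oxygen on an aromatic ring. A phenyl takes the place of a hydrogen on a saturated chain carbon bound to an oxygen on an aromatic ring, turning methoxy into benzyloxy. Within the data shown here, no measured pair shows this change alone, so any forecast is uncertain. Compound 1 also carries benzyloxy and gives 1000 nM, so stronger inhibition beyond the scatter is expected. The estimated step runs a 5.0-fold lower number from compound 2 to compound 3 (0.70 log units; beyond the scatter). For compound 3 the expected value is 2000 nM, with an estimated range from 500 nM to 8000 nM.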

Compound 3, concentration for 50% growth inhibition: 1000 nM
Compound 3: the middle estimate sits 2.0-fold (0.30 log units) above what was measured, within the range that was stated.
By their numbers in this assay, from the lowest: compounds 1 and 3 (each within the scatter of the next); then compound 2.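

In this assay, the change from methoxy to benzyloxy can now be read on its own, with 4-methylbenzyl on the sulfur held constant: a 10-fold lower number from compound 2 to compound 3 (1.00 log units; beyond the scatter) is the step it gives. The phenyl on this saturated chain carbon therefore goes with stronger inhibition of growth in this matched pair. With benzyloxy kept in place, putting 4-methylbenzyl in place of 4-fluorophenyl on the sulfur gives no change at the digits printed from compound 1 to compound 3 (within the scatter) as its step, so this pair does not separate these two sulfur groups.

As far as these compounds go, whether the gain needs the phenyl itself remains open, since an ethoxy, a longer chain or a benzyloxy carrying an amine could give a different result at this position. Nothing available explains why the phenyl goes with the stronger inhibition.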